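Urea to benzamide in a pyrazole series: growth inhibition

The source may hold more compounds than are shown below. What is called first, only, known or untested is meant among the compounds shown, and "the series" means these compounds.

Measured so far:
compound 1 `O=C(Nc1cccc(-n2cc(-c3ccncc3)c(-c3ccc(Cl)c(O)c3)n2)c1)Nc1ccc(Cl)c(Cl)c1` — 1040 nM
compound 2 `COc1cc(-c2nn(-c3cccc(NC(=O)Nc4cccc(C(F)(F)F)c4)c3)cc2-c2ccncc2)ccc1Cl` — 656 nM

In a functional assay on ACHN cells (Homo sapiens) for inhibition, read by sulforhodamine B assay, with a stated time of 48 h (a higher number here means a weaker inhibitor of growth, a lower number a stronger inhibitor of growth), compound 1 gives 1040 nM, and compound 2 gives 656 nM. Compound 2 carries the smaller of the two numbers, but its gap to compound 1 lies within the scatter, so the two are read as equivalent and neither is called the stronger.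

Compound 3 `COc1cc(-c2nn(-c3cccc(NC(=O)c4ccccc4)c3)cc2-c2ccncc2)ccc1Cl` is not yet measured. It differs from compound 2 by phenyl in place of (3-(trifluoromethyl)phenyl)amino on a carbonyl carbon; the shared core is kept. Among the measured compounds shown here, no step between measured compounds exists, so the expectation rests on the change alone. In this assay compound 3 is expected to give a higher number than compound 2, a step beyond the scatter. For compound 3 the expected value is 2500 nM, within 800 nM to 8000 nM. The step this estimate implies, a 3.8-fold higher number from compound 2 to compound 3 (0.58 log units; beyond the scatter), is expected to exceed the scatter.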

Compound 3, concentration for 50% growth inhibition: 754 nM
Beside the measured number, compound 3's estimate is 3.3-fold (0.52 log units) above it, and the stated range ends above it.
By their numbers in this assay, from the lowest: compounds 2, 3 and 1 (each within the scatter of the next).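

In this assay, among the compounds shown here, the change from (3-(trifluoromethyl)phenyl)amino to phenyl on the carbonyl carbon gives a 1.1-fold higher number from compound 2 to compound 3 (0.06 log units; within the scatter) and is the first one-place comparison. The two compounds therefore read as equivalent at this position, so in this assay the urea of compound 2 and the benzamide of compound 3 are not told apart, even though the change removes the amide-type hydrogen-bond donor and the trifluoromethyl group together. No measured evidence on these compounds accounts for this result.

With both parts changed at once, this single pair cannot show what either the amino nitrogen or the trifluoromethyl group contributes alone. Also open, going by these compounds, is how far this position accepts other groups on the carbonyl carbon, such as a nitrile-bearing phenyl or a piperidine.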